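The compounds below may be only part of what the source reports. "The series", "measured", "known", "first", "only" and "open" are said of these compounds alone.

Measured in a functional assay on the whole organism for inhibition, with Cicer arietinum as the target, with a stated time of 7 days; a higher number here means a weaker inhibitor, a lower number a stronger inhibitor:
- compound 1 `S=C(SCc1nc2ccccc2[nH]1)N1CCCC1`: 1800 nM
- compound 2 `S=C(SCc1nc2ccccc2[nH]1)N1CCCCC1`: 1660 nM
- compound 3 `CN(C)C(=S)SCc1nc2ccccc2[nH]1`: 2120 nM

Compound 3 has the highest of these three numbers, but its distance to each of the others is small: a 1.2-fold higher number from compound 1 to compound 3 (0.07 log units; within the scatter) and a 1.3-fold higher number from compound 2 to compound 3 (0.11 log units; within the scatter) both fall within the scatter, as does a 1.1-fold lower number from compound 1 to compound 2 (0.04 log units; within the scatter). Exchanging one group on the thiocarbonyl carbon for another has therefore left the read-out essentially unchanged across the measured set. Compound 4 `CCCNC(=S)SCc1nc2ccccc2[nH]1` carries the next variation at that same place: propylamino in place of dimethylamino on a thiocarbonyl carbon. Among the compounds with values here, the incoming group brings a hydrogen-bond donor, a feature none of the measured compounds has, so no measured step speaks to it directly; the three measured steps show only that the group at this position has so far been interchangeable. On that basis the expected change is small: a 1.0-fold lower number from compound 3 to compound 4 (0.00 log units; within the scatter). Compound 4 is estimated at 2100 nM in this assay, with a range from 1000 nM to 4500 nM.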

Compound 4, half-maximal inhibitory concentration: 2290 nM
The estimate for compound 4 lay 1.1-fold (0.04 log units) below the measured number; low and high end bracket the measured number.
By their numbers in this assay, from the lowest: compounds 2, 1, 3 and 4 (each within the scatter of the next).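

In this assay the step that brings in a hydrogen-bond donor at this position, propylamino in place of dimethylamino on a thiocarbonyl carbon, is a 1.1-fold higher number from compound 3 to compound 4 (0.03 log units; within the scatter) and so does not separate the two compounds. Setting the open chain against the two ring amines gives a 1.4-fold higher number from compound 2 to compound 4 (0.14 log units; within the scatter) and a 1.3-fold higher number from compound 1 to compound 4 (0.10 log units; within the scatter), and these steps also stay within the scatter, so among these four compounds neither the donor nor the loss of the ring shows any effect on the read-out. Nothing available explains why this position tolerates these changes.

On these data alone, whether a phenyl ring, a much longer chain or a chain ending in a carboxylic acid on the thiocarbonyl carbon would shift the number remains open. These compounds also leave open how changes to the shared core would act.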